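A pyrrolidin-1-yl group replaces an isopropylamino chain

The source may report more compounds than this note shows. Statements on the series, on what has been measured and on what is new or still open speak of the compounds shown alone.

Compound 1 `CCOC(=O)Nc1cccc2c1CN(C)CC2c1ccccc1`: 3.2 mg/kg
Compound 2 `CC(C)NCCC(=O)Nc1cccc2c1CN(C)CC2c1ccccc1`: 150 mg/kg

In a functional assay on the whole organism for inhibition, with Mus musculus as the target (a lower number here means that less compound is needed, a higher number that more compound is needed for the effect), compound 2 holds the higher of the two numbers, 150 mg/kg, well over compound 1 at 3.2 mg/kg. Compound 3 `CN1Cc2c(NC(=O)CN3CCCC3)cccc2C(c2ccccc2)C1` has pyrrolidin-1-yl in place of (isopropylamino)methyl on a saturated chain carbon bound to a carbonyl carbon. For the measured compounds named here, one measured step bears on this, and only loosely: a 47-fold higher number from compound 1 to compound 2 (1.67 log units; beyond the scatter). It is large, but it removes ethoxy, which plays no part in the new change, so it sets no size for it. Compound 3 keeps a nitrogen-bearing group on that chain, like compound 2 at 150 mg/kg, so a number in that region is expected. The expected change is small and slightly downward, a 1.5-fold lower number from compound 2 to compound 3 (0.18 log units; within the scatter), with no step beyond the scatter firmly anticipated. For compound 3 the estimate is 100 mg/kg, with an expected range from 30 mg/kg to 300 mg/kg.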

Compound 3, dose for half-maximal effect: 39 mg/kg
Estimate against measurement, compound 3: 2.6-fold (0.41 log units) above, within the range that was stated.
By their numbers in this assay, from the lowest: compound 1; then compound 3; then compound 2.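

In this assay, the result shows that this position responds to the form of the amine and not only to its presence: pyrrolidin-1-yl in place of (isopropylamino)methyl gives a 3.8-fold lower number from compound 2 to compound 3 (0.59 log units; beyond the scatter) even though both groups have the same heavy-atom count. Set against the ethoxy carbamate, however, (pyrrolidin-1-yl)methyl on the carbonyl carbon still leaves a 12-fold higher number from compound 1 to compound 3 (1.09 log units; beyond the scatter) and so closes only part of the gap seen with compound 2. Nothing available accounts for this shift, and the ring and the lost hydrogen-bond donor enter together, so their contributions cannot be separated.

From the compounds shown here alone, whether a piperidine ring, a morpholine ring or a dimethylamino group on the same carbon would keep or extend the shift remains open. So does whether a longer chain carrying the pyrrolidin-1-yl group would bring the number closer to that of compound 1.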